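Adding a second chloro to compound 2

A few compounds are considered here, and "the series" means these few. Any claim that something is new, unique, unknown or untested is made for them only; others in the source may bear on it.

In a functional assay on Raji cells (Homo sapiens) for cytotoxicity, with a stated time of 72 h (a higher number here means that more compound is needed for the effect, a lower number that less compound is needed), compound 1 (`C=C[C@@](C)(/C=C/c1ccc(Nc2ccc(OC)cc2)cc1)CCC=C(C)C`) gives > 26000 nM, which is a limit. Compound 2 (`C=C[C@@](C)(/C=C/c1ccc(-c2ccc(Cl)cc2)cc1)CCC=C(C)C`) gives > 26000 nM, also a limit. The evidence so far is the limit of > 26000 nM in this assay, at which 2 of the 2 values shown sit. Compound 3 (`C=C[C@@](C)(/C=C/c1ccc(-c2ccc(Cl)c(Cl)c2)cc1)CCC=C(C)C`) differs from compound 2 by chloro in place of hydrogen on an aromatic carbon, 4-chlorophenyl to 3,4-dichlorophenyl. Among the compounds with values here, the only measured step is a step that the two limits leave unreadable from compound 1 to compound 2, so it offers no size or direction to carry over, and no shift beyond the scatter is expected in this assay. The expected step is a step that the limit leaves unreadable from compound 2 to compound 3. For compound 3 the estimated value is 30000 nM, with an expected range of 12000 nM to 60000 nM.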

Compound 3, half-maximal effective concentration: > 26000 nM
Compound 3 gave a limit, no number; the forecaster's own chance of this, stated with the estimate: 80%; the middle value lies beyond the limit too.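

Within the data shown here, compound 1, compound 2 and compound 3 all give only a limit in this assay, so no step among them can be read. From the compounds shown here alone, how much of any of them the effect requires, and whether the second chloro changes that, stays open.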